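The source may report more compounds than this note shows. Statements on the series, on what has been measured and on what is new or still open speak of the compounds shown alone.

Three compounds have been measured in a functional assay on Malme-3M cells (Homo sapiens) for inhibition, read by sulforhodamine B assay, with a stated time of 48 h; on this read-out lower numbers stand for stronger inhibition of growth and higher numbers for weaker inhibition of growth:
Compound 1, `COc1ccc(-c2[nH]c3ccccc3c2/C=C(\C#N)S(=O)(=O)c2ccccc2)cc1`, gives 1200 nM.
Compound 2, `COc1ccc2[nH]c(-c3ccccc3)c(C=C(C#N)C#N)c2c1`, gives 4400 nM.
Compound 3, `COc1ccc(-c2[nH]c3ccc(OC)cc3c2/C=C(\C#N)S(=O)(=O)c2ccccc2)cc1`, gives 3200 nM.

Compound 1 holds the lowest of the three numbers; compound 3 is the nearest to it and compound 2 the furthest. For the measured compounds named here, the only step that changes one place, a 2.7-fold higher number from compound 1 to compound 3 (0.43 log units; beyond the scatter), puts a methoxy onto the core and moves the number beyond the scatter. Compound 4, `N#C/C(=C\c1c(-c2ccccc2)[nH]c2ccccc12)S(=O)(=O)c1ccccc1`, runs the other way: hydrogen in place of methoxy on an aromatic carbon. Going by the values given here, no measured step removes a methoxy at this position, so the evidence bears only loosely on compound 4. What it shows is that the number rose from compound 1 when a methoxy was added elsewhere, which leaves room for the removal here to help a little or to stay within the scatter. The step from compound 1 to compound 4 is expected to be small, estimated as a 1.2-fold lower number from compound 1 to compound 4 (0.08 log units; within the scatter). Compound 4 is therefore expected at 1000 nM, in the range 400 nM to 2500 nM.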

Compound 4, concentration for 50% growth inhibition: 8400 nM
For compound 4 the middle estimate is 8.4-fold (0.92 log units) below the measured one; measured number outside the range, above it.
By their numbers in this assay, from the lowest: compound 1; then compounds 3, 2 and 4 (each within the scatter of the next, the first and the last beyond it).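

In this assay, taking the methoxy away from this place, para to a large group, gives a 7.0-fold higher number from compound 1 to compound 4 (0.85 log units; beyond the scatter), so 4-methoxyphenyl goes with the lower number and plain phenyl with the higher one. The earlier step, a 2.7-fold higher number from compound 1 to compound 3 (0.43 log units; beyond the scatter), had shown a methoxy on the core going with a higher number, so the same group moves the number in opposite directions at these two places: adding it on the core and removing it from the 4-methoxyphenyl both raise the number. No measurement at hand offers an explanation for this difference.

Only methoxy and hydrogen are shown at this place, so it remains open how an ethoxy, a hydroxy or an amine there would compare. As far as these compounds go, whether the methoxy must sit at this exact place on the ring also remains open.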